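A few compounds are considered here, and "the series" means these few. Any claim that something is new, unique, unknown or untested is made for them only; others in the source may bear on it.

Compound 1 `COc1ccc(O)c(C(=O)/C=C/c2csc3ccccc23)c1` gives 750 nM
Compound 2 `COc1cc(O)c(C(=O)/C=C/c2csc3ccccc23)cc1OC` gives 710 nM

In a functional assay on MCF7 cells (Homo sapiens) for antiproliferative activity, read by sulforhodamine B assay, with a stated time of 72 h (a higher number here means a weaker inhibitor, a lower number a stronger inhibitor), compound 2 gives 710 nM and cannot be told apart, within the scatter, from compound 1 at 750 nM on this read-out. The next structure, compound 3 `COc1cc(O)c(C(=O)/C=C/c2csc3ccccc23)c(OC)c1OC`, carries a single change from compound 2, methoxy in place of hydrogen on an aromatic carbon and nothing else. The new methoxy sits ortho to a large group.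

Among the compounds with values here, one measured step bears on this, the same swap at another aromatic carbon, a 1.1-fold lower number from compound 1 to compound 2 (0.02 log units; within the scatter) and so no real change. Within the data shown here, that is thin evidence, since it is one step at a different place, and no measured compound shows a methoxy entering ortho to a large group. No step beyond the scatter is therefore expected in this assay for this change, although the range has to stay wide. The estimated step is a 1.1-fold higher number from compound 2 to compound 3 (0.05 log units; within the scatter) and it is expected to be small. Compound 3 is expected at 800 nM as a middle value, with an estimated range from 300 nM to 2500 nM when measured.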

Compound 3, half-maximal inhibitory concentration: 7700 nM
For compound 3 the middle estimate is 9.6-fold (0.98 log units) below the measured one; the whole stated range lies below it.
By their numbers in this assay, from the lowest: compounds 2 and 1 (each within the scatter of the next); then compound 3.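

In this assay, swapping hydrogen for methoxy is not a silent change at this position: it gives an 11-fold higher number from compound 2 to compound 3 (1.04 log units; beyond the scatter), making compound 3 a clearly weaker inhibitor, whereas the same swap at another aromatic carbon gave a 1.1-fold lower number from compound 1 to compound 2 (0.02 log units; within the scatter). The same small change can therefore have very different outcomes on this ring, depending on the carbon that receives it, and here that carbon is ortho to a large group and ortho to a methoxy group. No measurement among these compounds speaks to what lies behind the drop.

These compounds leave open whether the drop is particular to methoxy or would follow from other groups at this carbon, such as a fluorine, an amine or the longer ethoxy chain. They also leave open whether the new methoxy would have the same effect without the methoxy group it sits ortho to, which would show whether the drop depends on that pairing or on this carbon alone.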